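A pyridyl analogue in a series without measurable cytotoxicity

The compounds below may be only part of what the source reports. "The series", "measured", "known", "first", "only" and "open" are said of these compounds alone.

Three compounds sharing one core were examined in an ADME assay on HepG2 cells (Homo sapiens) for cytotoxicity, read by sulforhodamine B assay, with a stated time of 48 h; on this read-out lower numbers stand for higher toxicity in this test and higher numbers for lower toxicity in this test. Compound 1 `COc1nc2ccccc2cc1/C=C/c1noc(-c2ccc(Br)cc2)n1` carries a 4-bromophenyl group; in this assay compound 1 gives only a limit, > 195000 nM. Compound 2 `COc1nc2ccccc2cc1/C=C/c1noc(-c2ccccc2C)n1` carries a 2-methylphenyl group, and in this assay compound 2 likewise gives only a limit, > 230000 nM. Compound 3 `COc1cccc(-c2nc(/C=C/c3cc4ccccc4nc3OC)no2)c1` carries a 3-methoxyphenyl group, and in this assay compound 3 also stands at a limit, > 220000 nM. Because all three values are limits, as the limit of > 195000 nM in this assay, at which 1 of the 3 values shown sits, the limit of > 220000 nM in this assay, at which 1 of the 3 values shown sits, and the limit of > 230000 nM in this assay, at which 1 of the 3 values shown sits, show, compound 3 cannot be ranked against the other two, and the steps a step that the two limits leave unreadable from compound 1 to compound 3, a step that the two limits leave unreadable from compound 2 to compound 3 and a step that the two limits leave unreadable from compound 1 to compound 2 cannot be read.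

Compound 4 `COc1nc2ccccc2cc1/C=C/c1noc(-c2cccnc2)n1` differs from compound 3 by pyridin-3-yl in place of 3-methoxyphenyl on an aromatic carbon. Every measured step that bears on this change is unreadable, so no direction can be drawn from them. The step that the limit leaves unreadable from compound 3 to compound 4 is therefore expected to be none beyond the scatter. Compound 4 is expected to give 250000 nM in this assay, within a range from 100000 nM to 600000 nM, most probably again reported as a limit.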

Compound 4, half-maximal cytotoxic concentration: > 240000 nM
Compound 4 gave a limit, no number; the forecaster's own chance of this, stated with the estimate: 85%; the middle value does not contradict the limit.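

In this assay compound 4 gives only a limit, and the steps from compound 1, compound 2 and compound 3 to compound 4 cannot be read. The compounds shown leave open whether changing this group alters toxicity in this assay at all.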